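This account rests on a few compounds, and the source may have more. Where it says the series, first, only, none or still open, it means among the compounds named here.

Series notes. Compound 1 `N#CC1=C(N)Oc2c(c3nc4ccccc4nc3c3ccccc23)C12C(=O)N(Cc1cnnn1-c1ccc(F)cc1)c1ccccc12`, compound 2 `CCOc1ccc(-n2nncc2CN2C(=O)C3(C(C#N)=C(N)Oc4c3c3nc5ccccc5nc3c3ccccc43)c3ccccc32)cc1` and compound 3 `N#CC1=C(N)Oc2c(N)cc3nc4ccccc4nc3c2C12C(=O)N(Cc1cnnn1-c1ccccc1Cl)c1ccccc12` share one core and have been run in an ADME assay on L02 cells (Homo sapiens) for antiproliferative activity, read by MTT assay, with a stated time of 48 h; on this read-out lower numbers stand for stronger inhibition and higher numbers for weaker inhibition. In this assay compound 1 returns only the limit > 50000 nM. In this assay compound 2 likewise returns only the limit > 50000 nM. In this assay compound 3 also stands at the limit > 50000 nM, so compound 3 has no number of its own. All three values shown sit at the limit of > 50000 nM in this assay, at which 3 of the 3 values shown sit. Among the compounds with values here, the single measured step, a step that the two limits leave unreadable from compound 1 to compound 2, is for that reason of unreadable size.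

Compound 4 `Cc1ccc(C)c(-n2nncc2CN2C(=O)C3(C(C#N)=C(N)Oc4c(N)cc5nc6ccccc6nc5c43)c3ccccc32)c1` differs from compound 3 by 2,5-dimethylphenyl in place of 2-chlorophenyl on an aromatic nitrogen. Within the data shown here, no measured step touches this change directly, and the only step available gives no size. With every value shown at the limit of > 50000 nM in this assay, at which 3 of the 3 values shown sit, compound 4 is expected to remain at the limit as well, the expected step of a number no higher from compound 3 to compound 4 (the limit leaves the size open) being of no readable size. For compound 4 in this assay the estimate is 50000 nM, with a range from 25000 nM to 100000 nM.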

Compound 4, half-maximal inhibitory concentration: > 50000 nM
Compound 4 was reported as a limit; the forecaster's own chance of this, stated with the estimate: 85%; the middle value sits exactly at the limit.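

No step can be read from compound 3 to compound 4, since each is reported only as a limit in this assay: the limit of > 50000 nM in this assay, at which 4 of the 4 values shown sit. The compounds shown leave open what any change of aromatic group does in this assay, as none has a number of its own.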